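This account rests on a few compounds, and the source may have more. Where it says the series, first, only, none or still open, it means among the compounds named here.

Compound 1 `O=C(Nc1cccc(S(=O)(=O)C2CCCC2)n1)c1ccc(NCCO)cc1N1CCC2(CC1)CC2` in a functional assay on OVCAR-3 cells (Homo sapiens) for activation, with a stated time of 24 h; a higher number here means that more compound is needed for the effect, a lower number that less compound is needed: 177 nM
Compound 2 `CC(C)(CO)S(=O)(=O)c1cccc(NC(=O)c2cccnc2N2CCC3(CC2)CC3)c1` in this assay: 45900 nM
Compound 3 `CC(C)(C)NS(=O)(=O)c1cccc(NC(=O)c2cccnc2N2CCC3(CC2)CC3)c1` in this assay: 1030 nM

Among these three, compound 1 gives the lowest number in this assay; compound 3 comes nearest, and compound 2 lies furthest away, both beyond the scatter. Among the measured compounds shown here, the one step that can be read between measured compounds, a 45-fold lower number from compound 2 to compound 3 (1.65 log units; beyond the scatter), concerns a substituent on a sulfonyl sulfur and says nothing about the part of the molecule that changes here.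

Compound 4 `CC(C)(O)CNc1ccc(C(=O)Nc2cccc(S(=O)(=O)C3CCCC3)n2)c(N2CCC3(CC2)CC3)c1` differs from compound 1 in one place: 1-hydroxy-1-methylethyl in place of hydroxymethyl on a saturated chain carbon bound to a nitrogen on an aromatic ring. For the measured compounds named here, no measured pair in this set alters the chain carbon bound to the nitrogen on the aromatic ring, so there is no direct precedent, and the change adds only two carbons while keeping the hydroxyl and the count of donors and acceptors. The expectation is therefore a step of no size beyond the scatter, a 1.1-fold higher number from compound 1 to compound 4 (0.05 log units; within the scatter). Compound 4 is estimated to give 200 nM in this assay, within a range from 70 nM to 600 nM.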

Compound 4, half-maximal effective concentration: 228 nM
Compound 4: middle estimate off by 1.1-fold (0.06 log units), on the low side; measured number inside the range.
By their numbers in this assay, from the lowest: compounds 1 and 4 (each within the scatter of the next); then compound 3; then compound 2.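

In this assay, putting 1-hydroxy-1-methylethyl in place of hydroxymethyl on a saturated chain carbon bound to a nitrogen on an aromatic ring gives a 1.3-fold higher number from compound 1 to compound 4 (0.11 log units; within the scatter), so the read-out does not separate the 2-hydroxyethyl and 2-hydroxy-2-methylpropyl chains. Among the compounds shown here, this is the only measured pair here that touches this position, and it shows that the position can carry the larger of these two groups with no step beyond the scatter. No measurement shown here accounts for this result.

Both chains keep their hydroxyl, so the compounds shown leave open what a methoxy group, an amine, a carboxylic acid or a longer chain would do at this place. One pair also cannot show whether the same change would read alike on another core, such as that of compound 3, which has no such chain.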